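The source may hold more compounds than are shown below. What is called first, only, known or untested is meant among the compounds shown, and "the series" means these compounds.

Measured so far in a functional assay on Raji cells (Homo sapiens) for cytotoxicity, read by MTT assay, with a stated time of 48 h; on this read-out higher numbers stand for weaker inhibition and lower numbers for stronger inhibition:
compound 1 `Cc1ccc(Cn2c(/C=C3\SC(=S)N(CC(=O)O)C3=O)nc3cc(F)ccc32)cc1`: 3280 nM
compound 2 `Cc1ccc(Cn2c(/C=C3\SC(=S)N(CC(=O)O)C3=O)nc3ccc(F)cc32)cc1`: 2440 nM
compound 3 `COc1ccc2c(c1)nc(/C=C1\SC(=S)N(CC(=O)O)C1=O)n2Cc1ccc(C)cc1`: 1790 nM

All three values lie within the scatter of one another, so no ordering among them is drawn. Compound 1 and compound 2 share the same atoms joined differently; the difference between the two cores is not broken down here. From compound 1 to compound 3 the change is methoxy in place of fluoro on an aromatic carbon, and this gave a 1.8-fold lower number from compound 1 to compound 3 (0.26 log units; within the scatter). Compound 4 `COc1ccc2nc(/C=C3\SC(=S)N(CC(=O)O)C3=O)n(Cc3ccc(C)cc3)c2c1` is not yet measured; it carries the same change, (methoxy in place of fluoro on an aromatic carbon), placed on the core of compound 2.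

In this assay compound 4 is expected to show a step of about a 1.7-fold lower number from compound 2 to compound 4 (0.24 log units; within the scatter), matched to the earlier step because the measured pair gave a 1.8-fold lower number from compound 1 to compound 3 (0.26 log units; within the scatter), which itself sits within the scatter. Compound 4 is therefore estimated at 1400 nM, with an expected range from 700 nM to 2900 nM.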

Compound 4, half-maximal inhibitory concentration: 10800 nM
Beside the measured number, compound 4's estimate is 7.7-fold (0.89 log units) below it; measured number outside the range, above it.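

In this assay methoxy in place of fluoro gives a 4.4-fold higher number from compound 2 to compound 4 (0.65 log units; beyond the scatter), and the step does not carry over unchanged from one core to the other: the same change on two cores in this assay, a 1.8-fold lower number (0.26 log units; within the scatter) from compound 1 to compound 3 and a 4.4-fold higher number (0.65 log units; beyond the scatter) from compound 2 to compound 4, 8.1-fold (0.91 log units) apart, beyond the scatter of two such steps. Among these compounds, for these two pairs, the step measured on the core of compound 1 is thus no guide to the step on the core of compound 2. Two pairs do not give a rule for the series, and they do not show what in the two cores separates the outcomes.

The compounds shown leave open whether a chloro, hydroxyl or amine group in place of fluoro would also split between the two cores. As far as these compounds go, it also remains open whether the split persists with an amide in place of the carboxylic acid.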